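Moving the Fluorine Around the Outer Ring

This account rests on a few compounds, and the source may have more. Where it says the series, first, only, none or still open, it means among the compounds named here.

Of the compounds shown here, three sharing one core have been tested in a functional assay on Jurkat cells (Homo sapiens) for activation, with a stated time of 24 h; a lower number here means that less compound is needed, a higher number that more compound is needed for the effect. Compound 1 `O=[N+]([O-])c1ccc(NCc2ccccc2O)cc1` is reported as "not active" (no number reported) in this assay. Compound 2 `Oc1ccccc1CNc1ccc(N2CCNCC2)cc1` is likewise reported as "not active" (no number reported) in this assay. Compound 3 `Oc1ccccc1CNc1ccc(-c2cccc(F)c2)cc1` is the only one of the three with a number: in this assay compound 3 gives 2020 nM, so it stands alone with a measured value, and the other two entries offer no number to set beside it. Compound 4 `Oc1ccccc1CNc1ccc(-c2ccccc2F)cc1` differs from compound 3 in one place: 2-fluorophenyl in place of 3-fluorophenyl on an aromatic carbon. Among the measured compounds shown here, no step between two measured compounds exists in this set, so nothing here shows how such a move of the fluorine tends to shift the read-out. The expectation is therefore that a 1.2-fold higher number from compound 3 to compound 4 (0.09 log units; within the scatter) in this assay stays within the usual scatter, with no clear direction. Compound 4 is estimated to give 2500 nM in this assay, with a range from 800 nM to 8000 nM.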

Compound 4, half-maximal effective concentration: 2150 nM
The estimate for compound 4 lay 1.2-fold (0.07 log units) above the measured number; the measured number falls inside the stated range.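

The fluorine on the outer ring now has its first comparison: in this assay 2-fluorophenyl in place of 3-fluorophenyl gives a 1.1-fold higher number from compound 3 to compound 4 (0.03 log units; within the scatter) and so stays within the scatter. These two compounds hold the same atoms joined differently, and this read-out does not tell the two placements of the fluorine apart. Nothing at hand offers an explanation for this result.

Open, going by these compounds, is how, in this assay and on the same shared core, a plain phenyl or a phenyl carrying a nitrile or a carboxylic acid would compare with compound 3 and compound 4. Also open, on these data alone, is what separates these two compounds from compound 1 and compound 2, which carry other groups in place of the fluorophenyl and are both reported as not active.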